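Swapping nitrophenyl for furan on a cytotoxic lactone core

The source may hold more compounds than are shown below. What is called first, only, known or untested is meant among the compounds shown, and "the series" means these compounds.

Of the compounds shown here, two have been tested in a functional assay on SW 1116 cells (Homo sapiens) for cytotoxicity, read by MTT assay, with a stated time of 24 h, tested at 10 ug/mL; on this read-out higher numbers stand for a weaker effect at the one concentration tested and lower numbers for a stronger effect. Compound 1, `CC1(C)CC(=O)C2=C(C1)OC(=O)C(NC(=O)c1ccccc1)C2c1ccc([N+](=O)[O-])cc1`, gives 46.6% in this assay. Compound 2, `O=C1CCCC2=C1C(c1ccco1)C(NC(=O)c1ccccc1)C(=O)O2`, gives 74.2% in this assay. Of these two numbers compound 1 holds the lower one, and the gap up to compound 2 lies beyond the usual scatter, so compound 1 shows the stronger effect of the pair. Going by the values given here, no single-change step between measured compounds is available. Compound 3, `CC1(C)CC(=O)C2=C(C1)OC(=O)C(NC(=O)c1ccccc1)C2c1ccco1`, has not yet been measured. It differs from compound 1 in one place: furan-2-yl in place of 4-nitrophenyl on a saturated ring carbon. Compound 3 carries the same furan-2-yl group as compound 2, which gives the higher number, so the step is expected to raise the read-out, estimated as a number 19.4 percentage points higher from compound 1 to compound 3 (beyond the scatter), beyond the scatter. Compound 3 is thus expected to give about 66% in this assay, with a likely range from 50% to 82%.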

Compound 3, a percentage reported as activity, at one concentration (the size of the read-out at that concentration, not a potency): 42%
Compound 3: the middle estimate sits 24 percentage points above what was measured; the measured number lies below the stated range.
By their numbers in this assay, from the lowest: compounds 3 and 1 (each within the scatter of the next); then compound 2.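

In this assay putting furan-2-yl in place of 4-nitrophenyl on this saturated ring carbon gives a number 4.6 percentage points lower from compound 1 to compound 3 (within the scatter) and so the two compounds cannot be told apart on this read-out. The effect of compound 1 therefore does not depend on the 4-nitrophenyl group, since a five-membered aromatic ring with no nitro group serves equally well at this position. Furan-2-yl alone also does not set the number, as compound 3 gives 42% and compound 2 gives 74.2% even though both carry that group.

Nothing at hand gives a reason for this outcome. Going by these compounds, whether an unsubstituted phenyl, an amine or a longer chain on this ring carbon would keep the effect remains open.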